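This account rests on a few compounds, and the source may have more. Where it says the series, first, only, none or still open, it means among the compounds named here.

Of the compounds shown here, three sharing one core have been measured in an ADME assay on microsomes from liver (Mus musculus) for metabolic stability, read by LC-MS, using NADPH, tested at 1 uM; on this read-out lower numbers stand for a shorter-lived compound and higher numbers for a longer-lived compound. Compound 1 `Nc1nc(-c2cc(Br)cc(C(F)(F)F)c2)c(C(=O)c2ccccc2Cl)s1` gives 0.0867 h, compound 2 `Nc1nc(-c2cc(C(F)(F)F)cc(C(F)(F)F)c2)c(C(=O)c2ccccc2Cl)s1` gives 0.123 h, and compound 3 `COc1ccccc1C(=O)c1sc(N)nc1-c1cc(C(F)(F)F)cc(C(F)(F)F)c1` gives 0.0867 h. Compound 3 thus matches compound 1 at the digits shown, and all three numbers lie within the usual scatter of one another.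

The next compound, compound 4 `COc1ccccc1C(=O)c1sc(N)nc1-c1cc(Br)cc(C(F)(F)F)c1`, differs from compound 3 by a single swap: bromo in place of trifluoromethyl on an aromatic carbon. The closest guide is a 1.4-fold higher number from compound 1 to compound 2 (0.15 log units; within the scatter), which is the same swap run the opposite way, with chloro in place of methoxy. The other measured step, a 1.4-fold lower number from compound 2 to compound 3 (0.15 log units; within the scatter), matters too, since compound 4 carries the methoxy group. Read backwards, the first step hints at a slightly lower number, but it is too small to count as a real change. The expected result in this assay is therefore a 1.3-fold lower number from compound 3 to compound 4 (0.13 log units; within the scatter), a step not expected to exceed the scatter. The estimated half-life of compound 4 is 0.065 h, with an expected range from 0.035 h to 0.12 h.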

Compound 4, half-life: 0.0383 h
The estimate for compound 4 lay 1.7-fold (0.23 log units) above the measured number; low and high end bracket the measured number.
By their numbers in this assay, from the lowest: compound 4; then compounds 1, 3 and 2 (each within the scatter of the next).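

In this assay, the swap to bromo from trifluoromethyl on this aromatic carbon gives a step beyond the scatter, a 2.3-fold lower number from compound 3 to compound 4 (0.35 log units; beyond the scatter), yet it cannot be told apart from the same change on the chloro compounds: the same change on two cores in this assay, a 1.4-fold higher number (0.15 log units; within the scatter) from compound 1 to compound 2 and a 2.3-fold higher number (0.35 log units; beyond the scatter) from compound 4 to compound 3, 1.6-fold (0.20 log units) apart, within the scatter of two such steps

The swap to methoxy from chloro reads the same way, with a 2.3-fold lower number from compound 1 to compound 4 (0.35 log units; beyond the scatter), and again no firm gap from its counterpart: the same change on two cores in this assay, a 1.4-fold lower number (0.15 log units; within the scatter) from compound 2 to compound 3 and a 2.3-fold lower number (0.35 log units; beyond the scatter) from compound 1 to compound 4, 1.6-fold (0.20 log units) apart, within the scatter of two such steps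

So neither change measurably depends on the other, and of the steps shown, only those ending at compound 4 clear the scatter.

The compounds shown carry only bromo or trifluoromethyl at this place, so whether a nitrile, a methyl or an amine there would behave alike stays open. Which part of these compounds is broken down also stays unknown.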